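Aryl exchange at the amine-bearing carbon: compound 4

A few compounds are considered here, and "the series" means these few. Any claim that something is new, unique, unknown or untested is made for them only; others in the source may bear on it.

Measured so far in a functional assay on THP-1 cells (Homo sapiens); a lower number here means a smaller maximal response, a higher number a larger maximal response: compound 1 `CCSC[C@@](O)([C@@H](Nc1cccc2nc(C)ccc12)c1ccc(C)cc1)C(F)(F)F` gives 87%; compound 2 `CCSC[C@@](O)([C@@H](Nc1cccc2nc(C)ccc12)c1ccc(OC)cc1F)C(F)(F)F` gives 85%; compound 3 `CCSC[C@@](O)([C@@H](Nc1cccc2nc(C)ccc12)c1ccc(OC)c(F)c1)C(F)(F)F` gives 82%.

Compound 3 holds the lowest of the three numbers, but its gaps to the others are within the scatter, as seen in a number 5 percentage points lower from compound 1 to compound 3 (within the scatter) and a number 3 percentage points lower from compound 2 to compound 3 (within the scatter). Compound 4 `CCSC[C@@](O)([C@@H](Nc1cccc2nc(C)ccc12)c1ccc(Cl)c(F)c1O)C(F)(F)F` differs from compound 3 as follows: 4-chloro-3-fluoro-2-hydroxyphenyl in place of 3-fluoro-4-methoxyphenyl on a saturated chain carbon bound to a nitrogen on an aromatic ring and a saturated chain carbon. All three measured steps exchange the aryl group at this same place, and none moved beyond the scatter: a number 2 percentage points lower from compound 1 to compound 2 (within the scatter), a number 5 percentage points lower from compound 1 to compound 3 (within the scatter), a number 3 percentage points lower from compound 2 to compound 3 (within the scatter). None of them brings in a hydroxy donor or a chlorine, so the change to compound 4 is only partly covered. Among the compounds with values here, still, the series so far suggests the maximal response is little affected by this aryl group, and for compound 4 a step of no change at the digits printed from compound 3 to compound 4 (within the scatter) is expected, within the scatter. Compound 4 is therefore estimated at 82%, with a range from 70% to 94%.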

Compound 4, largest response reached (Emax), in percent of the reference or control that the assay uses: 107%
The estimate for compound 4 lay 25 percentage points below the measured number; the whole stated range lies below it.
By their numbers in this assay, from the lowest: compounds 3, 2 and 1 (each within the scatter of the next); then compound 4.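

In this assay the aryl group on this saturated chain carbon can move the maximal response after all, with a number 25 percentage points higher from compound 3 to compound 4 (beyond the scatter) as well as a number 22 percentage points higher from compound 2 to compound 4 (beyond the scatter) and a number 20 percentage points higher from compound 1 to compound 4 (beyond the scatter) while the earlier aryl exchanges stayed within the scatter. Within the data shown here, the 4-chloro-3-fluoro-2-hydroxyphenyl group brings in the hydroxy and the chlorine together, and this is the only aryl group here that carries either. No evidence at hand bears on the cause of this rise.

Which of the two groups carries the rise remains open. Also open, going by these compounds, is whether an amine or a carboxylic acid in place of the hydroxy would keep the response.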